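Sulfur for Selenium: One Swap on a Shared Core

A few compounds are considered here, and "the series" means these few. Any claim that something is new, unique, unknown or untested is made for them only; others in the source may bear on it.

Among the compounds with values here, in a functional assay on MCF7 cells (Homo sapiens) for cytotoxicity, read by MTT assay, with a stated time of 72 h (a lower number here means that less compound is tolerated, a higher number that more compound is tolerated), compound 3 `C[Se]/C(=N\C(=O)c1cnc2ccccc2c1)NC(=O)c1cnc2ccccc2c1` gives 60700 nM, the only reading in this set that is a number rather than a limit of the assay. Compound 1 `CS/C(=N\C(=O)c1ccno1)NC(=O)c1ccno1` returns only the assay limit, > 100000 nM. Compound 2 `CS/C(=N\C(=O)c1ccco1)NC(=O)c1ccco1` likewise returns only the assay limit, > 100000 nM. Two of the three results therefore sit at the limit of > 100000 nM in this assay, at which 2 of the 3 values shown sit. Compound 4 `CS/C(=N\C(=O)c1cnc2ccccc2c1)NC(=O)c1cnc2ccccc2c1` differs from compound 3 in one place: a group of 2 heavy atoms (1 carbon, 1 sulfur; no ring) in place of a group of 2 heavy atoms (1 carbon, 1 selenium; no ring), on a carbon with a double bond to nitrogen. Within the data shown here, no step between measured compounds is available, but compound 1 and compound 2 both carry the methylsulfanyl group and both stop at the limit, so a step towards weaker cytotoxicity in this assay is expected for compound 4, plausibly beyond the scatter. The estimate for compound 4 is 150000 nM (range 50000 nM to 400000 nM), an expected step of a 2.5-fold higher number from compound 3 to compound 4 (0.39 log units; beyond the scatter).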

Compound 4, concentration lethal to 50% of the cells: > 100000 nM
Compound 4: no number, only a limit; the forecaster's own chance of this, stated with the estimate: 60%; the middle value does not contradict the limit.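

Within the data shown here, with the shared core held fixed, selenium to sulfur on a carbon with a double bond to nitrogen gives the only direct comparison at this position in this assay: an at least 1.6-fold higher number from compound 3 to compound 4 (0.21 log units; that floor lies within the scatter). Compound 4 returns a limit rather than a number, so this step is only a floor. Compound 1, compound 2 and compound 4, all carrying methylsulfanyl, stop at one ceiling: the limit of > 100000 nM in this assay, at which 3 of the 4 values shown sit.

Going by these compounds, the true size of the step stays open, as does whether it would clear the scatter. On these data alone, how an amine or a longer chain in this place would read in this assay is also open.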